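Trading the Methylpiperazinyl Chain for a Dimethylamino Group

The compounds below may be only part of what the source reports. "The series", "measured", "known", "first", "only" and "open" are said of these compounds alone.

Three measured compounds share one core and differ only in the amine carried on a chain from an aromatic oxygen. Compound 1 `O=c1cc(-c2ccccc2)oc2cc(OCc3ccccc3)c(OCCCN3CCCC3)c(O)c12` gives in a functional assay on BCG823 cells (Homo sapiens) for antiproliferative activity, read by MTT assay, with a stated time of 48 h (a higher number here means a weaker inhibitor, a lower number a stronger inhibitor), only a limit, > 100000 nM. Compound 2 `CN1CCN(CCCOc2c(OCc3ccccc3)cc3oc(-c4ccccc4)cc(=O)c3c2O)CC1` gives 4100 nM in this assay, and compound 3 `CN1CCN(CCCCOc2c(OCc3ccccc3)cc3oc(-c4ccccc4)cc(=O)c3c2O)CC1` gives 7200 nM; compound 3 holds the higher of the two numbers, yet a 1.8-fold higher number from compound 2 to compound 3 (0.24 log units; within the scatter). The change to compound 4 `CN(C)CCCOc1c(OCc2ccccc2)cc2oc(-c3ccccc3)cc(=O)c2c1O` is dimethylamino in place of (4-methylpiperazin-1-yl)methyl on a saturated chain carbon, three bonds along the chain from an oxygen on an aromatic ring. The step of an at least 13-fold lower number from compound 1 to compound 3 (1.14 log units; beyond the scatter) shows that (4-methylpiperazin-1-yl)methyl gave a far lower number than pyrrolidin-1-yl, where compound 1 sits at a limit (the limit of > 100000 nM in this assay, at which 1 of the 3 values shown sits); giving up that group for dimethylamino is expected to push the number back up. Compound 4 is therefore estimated at 30000 nM, ranging from 8000 nM to 100000 nM, an expected step of a 4.2-fold higher number from compound 3 to compound 4 (0.62 log units; beyond the scatter).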

Compound 4, half-maximal inhibitory concentration: 5500 nM
For compound 4 the middle estimate is 5.5-fold (0.74 log units) above the measured one, outside the stated range (below it).
By their numbers in this assay, from the lowest: compounds 2, 4 and 3 (each within the scatter of the next). At a limit, above all of these: compound 1.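

In this assay, the ring of the methylpiperazinyl group turns out not to be required at this chain position: the step of a 1.3-fold lower number from compound 3 to compound 4 (0.12 log units; within the scatter) and the step of a 1.3-fold higher number from compound 2 to compound 4 (0.13 log units; within the scatter) show that the much smaller, open dimethylamino group holds the same level. Compound 1, with pyrrolidin-1-yl, goes against any simple reading by amine size, and the step of an at least 18-fold lower number from compound 1 to compound 4 (1.25 log units; beyond the scatter) rests on a limit: the limit of > 100000 nM in this assay, at which 1 of the 4 values shown sits.

Still open, from the compounds shown here alone, is whether diethylamino, morpholin-4-yl or piperidin-1-yl on this chain would stay at that level or fall away like pyrrolidin-1-yl.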